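A few compounds are considered here, and "the series" means these few. Any claim that something is new, unique, unknown or untested is made for them only; others in the source may bear on it.

In a functional assay on SW480 cells (Homo sapiens) for inhibition (on this read-out lower numbers stand for stronger inhibition of growth and higher numbers for weaker inhibition of growth), compound 1 `Cc1c(C(=O)Nc2ccc3ccccc3n2)cnn1-c1ccccc1` gives 23900 nM. Within the data shown here, compound 2 `Cc1cccc(C)c1-n1ncc(C(=O)Nc2ccc3ccccc3n2)c1C` gives 7200 nM in this assay, the lowest of the two numbers measured so far. Among the measured compounds shown here, the only measured step is a 3.3-fold lower number from compound 1 to compound 2 (0.52 log units; beyond the scatter), a modest gain from replacing the group on the aromatic nitrogen. Compound 3 `Cc1c(C(=O)Nc2ccc3ccccc3n2)cnn1-c1c(F)cccc1Br` alters that same group once more: 2-bromo-6-fluorophenyl in place of 2,6-dimethylphenyl on an aromatic nitrogen. Since both compound 2 and compound 3 carry a twice-substituted phenyl there, little change is expected, and the expected step is a 1.0-fold lower number from compound 2 to compound 3 (0.01 log units; within the scatter). Compound 3 is therefore estimated at 7000 nM, within a range from 2500 nM to 20000 nM.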

Compound 3, concentration for 50% growth inhibition: 3900 nM
Beside the measured number, compound 3's estimate is 1.8-fold (0.25 log units) above it; measured number inside the range.
By their numbers in this assay, from the lowest: compounds 3 and 2 (each within the scatter of the next); then compound 1.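

In this assay the change gives a 1.8-fold lower number from compound 2 to compound 3 (0.27 log units; within the scatter), so at this position two methyl groups and a bromine with a fluorine on the phenyl cannot be told apart. Against the plain phenyl, the new group gives a 6.1-fold lower number from compound 1 to compound 3 (0.79 log units; beyond the scatter), so a second twice-substituted phenyl also stands clear of phenyl, which compound 2 alone could not show. Nothing measured here explains this difference from phenyl. On these data alone, whether a single substituent on the phenyl would be enough stays open, as does the effect of an amine or a carboxylic acid on that ring.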